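The source may hold more compounds than are shown below. What is called first, only, known or untested is meant among the compounds shown, and "the series" means these compounds.

Measured so far in an ADME assay on HCT-116 cells (Homo sapiens) for cytotoxicity, read by CellTiter-Glo, with a stated time of 72 h; a higher number here means a weaker inhibitor, a lower number a stronger inhibitor:
compound 1 `COc1ccc(S(=O)(=O)N2CCC(N3CCC(C)CC3)CC2)cc1OC` gives only the limit > 5000 nM.
compound 2 `CC1CCN(C2CCN(S(=O)(=O)c3cccc(-c4ccc(F)cc4)c3)CC2)CC1` gives only the limit > 5000 nM.
compound 3 `CC1CCN(C2CCN(S(=O)(=O)c3ccc(F)cc3F)CC2)CC1` gives only the limit > 5000 nM.

Compound 3 stands at the limit of > 5000 nM in this assay, at which 3 of the 3 values shown sit. Among the measured compounds shown here, its value is a limit and not a number, and compound 1 and compound 2 sit at the same limit, so no order among the three can be read and no step between measured compounds is available. Nothing in the set yet separates one aryl sulfonyl substituent from another in this assay.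

Compound 4 `CC1CCN(C2CCN(S(=O)(=O)c3ccc(Cl)cc3Cl)CC2)CC1` is the next entry. The change from compound 3 is 2,4-dichlorophenyl in place of 2,4-difluorophenyl on a sulfonyl sulfur. For the measured compounds named here, with every measured value at the limit, no measured step sets the size or direction of such a change in this assay. The expected step is none beyond the scatter, a step that the limit leaves unreadable from compound 3 to compound 4. It is estimated that compound 4 most likely again returns only a limit rather than a number. On that basis compound 4 is expected in this assay near 8000 nM, with a range of 2000 nM to 40000 nM.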

Compound 4, half-maximal inhibitory concentration: > 5000 nM
Compound 4: no number, only a limit; the forecaster's own chance of this, stated with the estimate: 75%; the middle value is on the limit's open side.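

In this assay compound 4 gives > 5000 nM, which is a limit and not a number. No step can be read from compound 3 to compound 4, and the set offers no number to compare: the limit of > 5000 nM in this assay, at which 4 of the 4 values shown sit.

Open, as far as these compounds go, is whether any aryl sulfonyl substituent on the shared core gives a numerical value in this assay.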